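The source may report more compounds than this note shows. Statements on the series, on what has been measured and on what is new or still open speak of the compounds shown alone.

Measured compounds:
Compound 1, `C(#Cc1ccccn1)C1=CC(Nc2cccnc2)CCC1`: 8.6 nM
Compound 2, `Cc1cccc(S(=O)(=O)N2CC=C(C#Cc3ccccn3)CC2)c1`: 8.2 nM
Compound 3, `Cc1ccc(S(=O)(=O)N2CC=C(C#Cc3ccccn3)CC2)cc1`: 7.9 nM

All three were tested in an in vitro functional assay on Ltk cells for inhibition of metabotropic glutamate receptor 5 (Homo sapiens), read by calcium flux; on this read-out lower numbers stand for stronger inhibition and higher numbers for weaker inhibition. Compound 3 sits within the usual scatter of both of the others: its separation from compound 2 is a 1.0-fold lower number from compound 2 to compound 3 (0.02 log units; within the scatter), and the gap to compound 1 is of the same small size, so the three values cannot be told apart.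

Compound 4, `O=S(=O)(c1ccc(Br)cc1)N1CC=C(C#Cc2ccccn2)CC1`, has not yet been measured. It differs from compound 3 in one place: bromo in place of methyl on an aromatic carbon. Going by the values given here, the only measured step that touches the same part of the molecule is the one from compound 2 to compound 3, which moved the methyl from one position on the ring to another and gave a 1.0-fold lower number from compound 2 to compound 3 (0.02 log units; within the scatter). Among the compounds with values here, no measured step exchanges methyl for bromo, so the data leave that change untested. Within the data shown here, since the one step on this ring stayed within the scatter, compound 4 is expected to give 8.5 nM, with a range from 3.5 nM to 22 nM. The estimated change is a 1.1-fold higher number from compound 3 to compound 4 (0.03 log units; within the scatter).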

Compound 4, half-maximal inhibitory concentration: 2.2 nM
Beside the measured number, compound 4's estimate is 3.9-fold (0.59 log units) above it, outside the stated range (below it).
By their numbers in this assay, from the lowest: compound 4; then compounds 3, 2 and 1 (each within the scatter of the next).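

The group at this place on the aromatic ring matters more than the methyl shift suggested. In this assay, going by these compounds alone, moving the methyl gave only a 1.0-fold lower number from compound 2 to compound 3 (0.02 log units; within the scatter), whereas bromo in place of methyl gives a 3.6-fold lower number from compound 3 to compound 4 (0.56 log units; beyond the scatter) and is the first change in this set to pass beyond the scatter. Reached from the other methyl compound, 4-bromophenyl in place of 3-methylphenyl gives a 3.7-fold lower number from compound 2 to compound 4 (0.57 log units; beyond the scatter), a step of much the same size, and nothing available here explains why one heavy atom exchanged for another has this effect.

From the compounds shown here alone, it remains open whether chloro, fluoro or methoxy at this place would match bromo. Also open, going by these compounds, is whether bromo at the ring position held by the methyl of compound 2 would give a similar number.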